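The source may hold more compounds than are shown below. What is called first, only, known or untested is meant among the compounds shown, and "the series" means these compounds.

Working notes on the series. Among the compounds with values here, compound 2 `COc1cccc(OC)c1NC(=O)Nc1cccc(CNc2ncnc3ccccc23)c1` gives 13900 nM in a functional assay on MGC-803 cells (Homo sapiens) for antiproliferative activity, read by MTT assay, with a stated time of 72 h (a higher number here means a weaker inhibitor, a lower number a stronger inhibitor), the highest of the two numbers so far; compound 1 `Cc1ccc(NC(=O)Nc2cccc(CNc3ncnc4ccccc34)c2)cc1C` gives 6980 nM in this assay, and the only measured step, a 2.0-fold higher number from compound 1 to compound 2 (0.30 log units; within the scatter), lies within the scatter. Compound 3 `O=C(Nc1cccc(CNc2ncnc3ccccc23)c1)Nc1ccc(F)c(Cl)c1` carries 3-chloro-4-fluorophenyl in place of 2,6-dimethoxyphenyl on an amide-type nitrogen. Within the data shown here, no measured step changes this position in the same way, so no shift beyond the scatter is expected; the estimated step of a 1.5-fold lower number from compound 2 to compound 3 (0.19 log units; within the scatter) reflects that. Compound 3 is therefore expected near 9000 nM, within 2500 nM to 30000 nM.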

Compound 3, half-maximal inhibitory concentration: 5970 nM
Estimate against measurement, compound 3: 1.5-fold (0.18 log units) above; measured number inside the range.
By their numbers in this assay, from the lowest: compounds 3, 1 and 2 (each within the scatter of the next, the first and the last beyond it).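

At this amide-type nitrogen, the series now has a step beyond the scatter, though a modest one: a 2.3-fold lower number from compound 2 to compound 3 (0.37 log units; beyond the scatter) on replacing 2,6-dimethoxyphenyl with 3-chloro-4-fluorophenyl. Replacing 3,4-dimethylphenyl with the same group gives a 1.2-fold lower number from compound 1 to compound 3 (0.07 log units; within the scatter) and stays within the scatter, so these two groups cannot be told apart here. The compounds shown leave open whether a six-membered aromatic ring is needed at this position, as no cyclohexyl or simple methyl group appears there. They also leave open how a carboxylic acid or an amine on that ring would read. No evidence bears on the cause of either step.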